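The source may hold more compounds than are shown below. What is called first, only, known or untested is meant among the compounds shown, and "the series" means these compounds.

In a functional assay on A549 cells (Homo sapiens) for cytotoxicity, read by MTT assay, with a stated time of 48 h (a higher number here means a weaker inhibitor, a lower number a stronger inhibitor), compound 1 (`COc1cc([C@@H]2C[C@@]2(CO)C(=O)Nc2ccccc2)cc(OC)c1OC`) gives 43200 nM and stands level with the other two measured compounds. Compound 2 (`CCOC(=O)[C@]1(C(=O)Nc2ccccc2Cl)C[C@@H]1c1cc(OC)c(OC)c(OC)c1`) gives 50900 nM and compound 3 (`COc1cc([C@@H]2C[C@@]2(CO)C(=O)NCc2ccc(C)cc2)cc(OC)c1OC`) gives 46300 nM in the same test. All three values lie within the scatter of one another, so the series reads as flat so far.

Compound 4 (`COc1cc([C@H]2C[C@]2(CO)C(=O)Nc2ccccc2)cc(OC)c1OC`) has not been measured. Its relation to compound 1 is a pure change of configuration (the two compounds have the same atoms and bonds and differ only in configuration as drawn: 2 of 2 stereo elements differ (all stereocentres are inverted: mirror images); a stereocentre at a saturated ring carbon is drawn S in compound 1 and R in compound 4; a stereocentre at a saturated ring carbon is drawn R in compound 1 and S in compound 4) with no group entering or leaving.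

For the measured compounds named here, only one measured step links two compounds that differ in one place. That step is a 1.1-fold higher number from compound 1 to compound 3 (0.03 log units; within the scatter) and it stays within the scatter. It concerns the amide substituent, not configuration, so it bears on the present change only indirectly. Going by the values given here, no pair of mirror images has been measured, and the data therefore give no direct reading of inversion and no ground for a direction.

No step beyond the scatter is expected in this assay and the range is kept wide for this untested kind of change. The estimated step is a 1.0-fold higher number from compound 1 to compound 4 (0.02 log units; within the scatter) and it is expected to lie within the scatter. For compound 4 the estimated value is 45000 nM with an expected range from 20000 nM to 95000 nM in this test.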

Compound 4, half-maximal inhibitory concentration: > 100000 nM
Compound 4: only a limit was reported; the forecaster's own chance of this, stated with the estimate: 10%; middle value at least 2.2-fold (0.34 log units) away from the limit.
By their numbers in this assay, from the lowest: compounds 1, 3 and 2 (each within the scatter of the next). At a limit, above all of these: compound 4.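

In this assay, for the compounds shown here, the first step beyond the scatter comes from configuration and not from the amide substituent: an at least 2.3-fold higher number from compound 1 to compound 4 (0.36 log units; beyond the scatter). Going by these compounds alone, the one earlier single-place step, a 1.1-fold higher number from compound 1 to compound 3 (0.03 log units; within the scatter), lies within the scatter, so the series no longer reads as flat, and the arrangement at the two ring stereocentres emerges as a sensitive feature of compound 1, with the step resting on inversion alone: the fact that compounds 1 and 4 differ only in the configuration as drawn. From the compounds shown here alone, compound 4 stands at a limit of this assay, > 100000 nM, so the printed step is a lower bound and the full size of the inversion step stays unknown: the limit of > 100000 nM in this assay, at which 1 of the 4 values shown sits.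

The compounds shown leave open whether one of the two stereocentres carries the step alone or both contribute, and whether inversion acts in the same way with 4-methylbenzyl on the amide nitrogen, as in compound 3. Also open, going by these compounds, is whether a carboxylic acid or an amine in place of the hydroxymethyl group of compound 1 would keep its number in this assay or shift it.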